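Pyridyl amide series: stereocentre inversion at the naphthyl-bearing carbon

The compounds below may be only part of what the source reports. "The series", "measured", "known", "first", "only" and "open" are said of these compounds alone.

Measured compounds, an assay on Jurkat cells for displacement of a labelled ligand from C-X-C chemokine receptor type 4 (Homo sapiens), tested at 10 uM; a higher number here means more inhibition at the concentration tested (going by the name of the read-out), a lower number less inhibition:
compound 1, `C[C@@H](NC(=O)[C@H](CCCNC(=N)N)NC(=O)c1ccc(CN(Cc2ccccn2)C(=O)c2ccc(F)cc2)cc1)c1cccc2ccccc12`, gives 3%
compound 2, `C[C@@H](NC(=O)[C@H](CCCNC(=N)N)NC(=O)c1ccc(CN(Cc2cccnc2)C(=O)c2ccc(F)cc2)cc1)c1cccc2ccccc12`, gives 11%
compound 3, `C[C@@H](NC(=O)[C@H](CCCNC(=N)N)NC(=O)c1ccc(CN(Cc2ccncc2)C(=O)c2ccc(F)cc2)cc1)c1cccc2ccccc12`, gives 6%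

All three compounds share one core and differ only in the pyridyl group on the saturated chain carbon bound to the amide-type nitrogen. The three numbers sit close together: a number 8 percentage points higher from compound 1 to compound 2 (within the scatter), a number 3 percentage points higher from compound 1 to compound 3 (within the scatter), a number 5 percentage points lower from compound 2 to compound 3 (within the scatter). Compound 2 holds the highest of the three numbers, but its gap to compound 3 and its gap to compound 1 are both within the scatter, so no order among the three can be read from this assay.

Compound 4, `C[C@H](NC(=O)[C@H](CCCNC(=N)N)NC(=O)c1ccc(CN(Cc2cccnc2)C(=O)c2ccc(F)cc2)cc1)c1cccc2ccccc12`, is the next compound. Against compound 2 the change is the two compounds have the same atoms and bonds; at least one stereo element is drawn with a configuration in one of them and without one in the other: 1 of 3 stereo elements differ; a stereocentre at a saturated chain carbon is drawn R in compound 2 and S in compound 4. For the measured compounds named here, none of the measured steps bears on this change: each of them swaps one pyridyl isomer for another and leaves every stereocentre as drawn, and all three steps were within the scatter. Going by the values given here, the pyridyl swaps shifted nothing beyond the scatter, and there is no measured pair that shows what an inversion at this stereocentre does in this assay. With the whole series sitting at low inhibition, the expectation for compound 4 is a number in the same low band, with a wide range, and the expected step of a number 5 percentage points lower from compound 2 to compound 4 (within the scatter) is within the scatter. The estimate for compound 4 is 6%, expected to fall between 0% and 20%.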

Compound 4, a percentage reported as inhibition, at one concentration (the size of the read-out at that concentration, not a potency): 14%
Compound 4: the middle estimate sits 8 percentage points below what was measured, within the range that was stated.
By their numbers in this assay, from the lowest: compounds 1, 3, 2 and 4 (each within the scatter of the next, the first and the last beyond it).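

In this assay the inversion at the saturated chain carbon, drawn R in compound 2 and S in compound 4, gives a number 3 percentage points higher from compound 2 to compound 4 (within the scatter), so this first measured pair at the stereocentre shows no readable effect of the change. The stereocentre therefore joins the pyridyl position as a place where no step beyond the scatter has been seen, and with compound 4 at 14%, the inversion does not lift this pyridin-3-yl compound out of the low band at the single concentration tested. The pair carries one reservation for any reading as a clean comparison of two defined configurations: the fact that one of compounds 2 and 4 is drawn with a defined configuration and the other without, at the place where they differ

Going by these compounds, with a single pair at this stereocentre, it remains open whether the inversion would read the same way in the pyridin-2-yl and pyridin-4-yl compounds. On these data alone, it also remains open whether a primary amine or a carboxylic acid in place of the pyridyl group, in either configuration, would move inhibition beyond the scatter of these values.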